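This account rests on a few compounds, and the source may have more. Where it says the series, first, only, none or still open, it means among the compounds named here.

Compound 3 `O=c1cc(-c2ccccc2)oc2cc(O)c(OCCCCN3CCCC3)c(O)c12` is the anchor of this account. In a functional assay on A549 cells (Homo sapiens) for antiproliferative activity, read by MTT assay, with a stated time of 48 h (on this read-out lower numbers stand for stronger inhibition and higher numbers for weaker inhibition), compound 3 gives 51000 nM, the highest of the two numbers measured here. Its nearest neighbour is compound 2 `O=c1cc(-c2ccccc2)oc2cc(OCc3ccccc3)c(OCCCCN3CCCCC3)c(O)c12`, which in this assay gives 1900 nM; compound 2 differs from compound 3 in two places, so no single step between them is shown. Compound 1 `O=c1cc(-c2ccccc2)oc2cc(O)c(OCCCN3CCCC3)c(O)c12` reaches only the limit of this assay, where compound 1 gives > 100000 nM (the limit of > 100000 nM in this assay, at which 1 of the 3 values shown sits). Among the measured compounds shown here, the one measured step, an at least 1.9-fold lower number from compound 1 to compound 3 (0.29 log units; that floor lies within the scatter), does not touch the ring that changes here.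

The step to compound 4 `O=c1cc(-c2ccccc2)oc2cc(O)c(OCCCCN3CCCCC3)c(O)c12` is piperidin-1-yl in place of pyrrolidin-1-yl on a saturated chain carbon, four bonds along the chain from an oxygen on an aromatic ring. For the measured compounds named here, no measured step bears directly on this ring change; the values of compound 2 and compound 3 in this assay show only that the piperidin-1-yl compound sits lower, with a second difference alongside. A modest lowering is therefore expected, a 1.7-fold lower number from compound 3 to compound 4 (0.23 log units; within the scatter), which stays near the scatter. Compound 4 is estimated at 30000 nM in this assay, with a range from 10000 nM to 90000 nM.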

Compound 4, half-maximal inhibitory concentration: 75000 nM
For compound 4 the middle estimate is 2.5-fold (0.40 log units) below the measured one; low and high end bracket the measured number.
By their numbers in this assay, from the lowest: compound 2; then compounds 3 and 4 (each within the scatter of the next). At a limit, above all of these: compound 1.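

In this assay, the ring change on this chain does not separate the two compounds: a 1.5-fold higher number from compound 3 to compound 4 (0.17 log units; within the scatter), which leaves piperidin-1-yl and pyrrolidin-1-yl indistinguishable here. The large step lies with the other change, hydrogen in place of benzyl on an oxygen on an aromatic ring: a 39-fold higher number from compound 2 to compound 4 (1.60 log units; beyond the scatter). The remaining step starts from a limit and gives only a floor, an at least 1.3-fold lower number from compound 1 to compound 4 (0.12 log units; that floor lies within the scatter): the limit of > 100000 nM in this assay, at which 1 of the 4 values shown sits.

As far as these compounds go, whether a benzyl group on that oxygen would bring the same large step with pyrrolidin-1-yl at the end of the chain remains open, as does the outcome with a methyl group on that oxygen. The compounds shown also leave open how an open-chain amine such as dimethylamino, or a morpholin-4-yl ring, would compare at the end of the chain.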